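The compounds below may be only part of what the source reports. "The series", "measured", "known", "first", "only" and "open" are said of these compounds alone.

Measured compounds:
- compound 1 `CSc1c(F)cccc1NCC1=NCCN1` — 7.76 nM
- compound 2 `CS(=O)(=O)c1ccc(Cl)cc1NCC1=NCCN1` — 2.82 nM

Both compounds were tested in a functional assay for agonist activity at Alpha-1A adrenergic receptor (Homo sapiens); a higher number here means that more compound is needed for the effect, a lower number that less compound is needed. Compound 1 has the higher of the two numbers; compound 2 gives the lower one, and the gap between them lies beyond the usual scatter of this assay. Going by the values given here, compound 2 differs from compound 1 in two places at once, so the pair does not isolate any single change; its values show only that a compound carrying a methylsulfonyl group can reach a lower number than compound 1.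

Compound 3 `CS(=O)(=O)c1c(F)cccc1NCC1=NCCN1` has not yet been measured. It differs from compound 1 in one place: methylsulfonyl in place of methylsulfanyl on an aromatic carbon. Among the compounds with values here, no measured pair mirrors this change alone, so the expectation rests on the two values at hand. Compound 2, which carries the same methylsulfonyl group, gives 2.82 nM. On that basis the step is expected to be a modest decrease, estimated at a 1.9-fold lower number from compound 1 to compound 3 (0.29 log units; within the scatter). Compound 3 is accordingly expected to give about 4 nM, with a range from 1.5 nM to 12 nM.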

Compound 3, half-maximal effective concentration: 24 nM
For compound 3 the middle estimate is 6.0-fold (0.78 log units) below the measured one; measured number above the stated range.
By their numbers in this assay, from the lowest: compound 2; then compound 1; then compound 3.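

In this assay, methylsulfonyl in place of methylsulfanyl on the aromatic carbon ortho to a fluoro group gives a 3.1-fold higher number from compound 1 to compound 3 (0.49 log units; beyond the scatter), a step beyond the usual scatter. Going by these compounds alone, this is the first change that can be read in one place alone, and it shows that, with the rest of compound 1 kept, the methylsulfanyl group goes with the lower number at this position. Methylsulfonyl thus does not bring a lower number by itself here, so the low number of compound 2, which differs from compound 1 in two places, cannot be credited to that group alone. Nothing at hand accounts for the direction or the size of this step.

Whether the same step would appear on a ring without the fluoro group, or with that group in another place, remains open, since the shown compounds hold no such matched pair. From the compounds shown here alone, how a methylsulfinyl group, an ethylsulfanyl chain or a primary amine would stand at this position also remains open.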